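Iodo Gives Way to Nitro: A Cytotoxicity Estimate

The source may hold more compounds than are shown below. What is called first, only, known or untested is meant among the compounds shown, and "the series" means these compounds.

For the measured compounds named here, in a functional assay on T98G cells (Homo sapiens) for cytotoxicity, read by MTT assay, with a stated time of 48 h (on this read-out higher numbers stand for weaker inhibition and lower numbers for stronger inhibition), compound 2 `C/C(=N\NC(=S)Nc1cccc(I)c1)c1ccccn1` gives 61 nM, the lowest of the two numbers measured so far. Compound 1 `C/C(=N/NC(=S)Nc1cccc([N+](=O)[O-])c1)c1ccccn1` gives 140 nM, and this gap lies beyond the usual scatter. The next compound to be measured is compound 3 `C/C(=N\NC(=S)Nc1cccc([N+](=O)[O-])c1)c1ccccn1`. It differs from compound 2 by having nitro in place of iodo on an aromatic carbon, meta to a large group: nitro in place of iodo on an aromatic carbon. Going by the values given here, no step between measured compounds shows this change directly, so the evidence is limited. Compound 1 also bears a nitro group and gives 140 nM, which points to a modest rise in the number rather than a large one. The expected step is a 2.0-fold higher number from compound 2 to compound 3 (0.29 log units; within the scatter), toward weaker inhibition in this assay. For compound 3 the estimated value is 120 nM, with an expected range from 40 nM to 350 nM.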

Compound 3, half-maximal inhibitory concentration: 140 nM
Estimate against measurement, compound 3: 1.2-fold (0.07 log units) below, within the range that was stated.
By their numbers in this assay, from the lowest: compound 2; then compounds 1 and 3 (each within the scatter of the next).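

Nitro in place of iodo on an aromatic carbon, meta to a large group, now has a direct reading in this assay as a 2.3-fold higher number from compound 2 to compound 3 (0.36 log units; beyond the scatter) and so the iodo compound holds the lower number, a difference the earlier compounds could only hint at. The second reading, no change at the digits printed from compound 1 to compound 3 (within the scatter), adds that the drawn configuration of the double bond leaves the nitro compounds at the same number in this read-out. That makes the nitro pair a clean test of configuration alone, with nothing else varying: the fact that compounds 1 and 3 differ only in the configuration as drawn.

On these data alone, whether the iodo compound would behave the same way under that switch of configuration remains open. So does how an amine or a carboxylic acid on this aromatic carbon would compare with iodo and nitro.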